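The compounds below may be only part of what the source reports. "The series", "measured", "known", "first", "only" and "open" are said of these compounds alone.

Measured so far:
- compound 1, `CCn1c(C(=O)NCCCN(C)C)ccc1C(CC)(CC)c1ccc(OCC(=O)C(C)(C)C)c(C)c1`: 96 nM
- compound 2, `C#CCNC(=O)c1ccc(C(CC)(CC)c2ccc(OCC(=O)C(C)(C)C)c(C)c2)n1CC`: 2200 nM
- compound 3, `C#CCNC(=O)c1ccc(C(CC)(CC)c2ccc(OCC(O)C(C)(C)C)c(C)c2)n1CC`: 240 nM

In an assay on HL-60 cells for agonist activity at vitamin D3 receptor (Homo sapiens), read by microscopy, with a stated time of 96 h (on this read-out lower numbers stand for an effect already at smaller amounts and higher numbers for an effect only at larger amounts of compound), compound 3 stands second of the three measured numbers: compound 1 gives a lower number, 96 nM, while compound 2 gives the highest, 2200 nM. The step from compound 2 to compound 3 was a 9.2-fold lower number from compound 2 to compound 3 (0.96 log units; beyond the scatter), and the step from compound 1 to compound 2 was a 23-fold higher number from compound 1 to compound 2 (1.36 log units; beyond the scatter).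

Compound 4, `CCn1c(C(=O)OCc2ccc(F)cc2)ccc1C(CC)(CC)c1ccc(OCC(O)C(C)(C)C)c(C)c1`, is the compound not yet measured. It differs from compound 3 in one place: (4-fluorobenzyl)oxy in place of propargylamino on a carbonyl carbon. The amide group that carried a hydrogen-bond donor in compound 3 is thus traded for an ester-type link carrying a fluorinated aromatic ring.

Neither measured step copies this change. Among the compounds with values here, the only step that touched the group on the carbonyl carbon, a 23-fold higher number from compound 1 to compound 2 (1.36 log units; beyond the scatter), was large, showing that this part of the structure can move the number strongly; the other step, a 9.2-fold lower number from compound 2 to compound 3 (0.96 log units; beyond the scatter), concerned the opposite end and does not bear directly. Within the data shown here, with no close precedent, the estimate for compound 4 is a moderate rise in number, a 2.5-fold higher number from compound 3 to compound 4 (0.40 log units; beyond the scatter), with wide uncertainty.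

Compound 4 is thus expected to give about 600 nM in this assay, within the range 120 nM to 3000 nM.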

Compound 4, half-maximal effective concentration: > 50000 nM
Compound 4: only a limit was reported; the forecaster's own chance of this, stated with the estimate: 5%; at least 83-fold (1.92 log units) between middle value and limit.
By their numbers in this assay, from the lowest: compound 1; then compound 3; then compound 2. At a limit, above all of these: compound 4.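

In this assay, putting (4-fluorobenzyl)oxy in place of propargylamino on the carbonyl carbon gave an at least 200-fold higher number from compound 3 to compound 4 (2.31 log units; beyond the scatter), the largest step among the compounds shown. The earlier step at this site, a 23-fold higher number from compound 1 to compound 2 (1.36 log units; beyond the scatter), changed only the chain on an amide-type nitrogen, whereas this change removes that nitrogen and its hydrogen-bond donor, so the site turns out to be far less forgiving of a swap in the link itself than the amides alone could show. The value of compound 4 is a limit of the assay and not a number, so the true size of the step stays unknown: the limit of > 50000 nM in this assay, at which 1 of the 4 values shown sits.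

The change replaces the amide link with an ester-type link, removes the triple bond and brings in a fluorinated aromatic ring all at once, so the compounds shown cannot say which of these matters. A 4-fluorobenzyl amide would keep the new ring on the amide link, and a small methyl ester would keep the ester-type link without that ring, so these two groups on the same carbonyl carbon would pull the effects apart.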